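A few compounds are considered here, and "the series" means these few. Any claim that something is new, unique, unknown or untested is made for them only; others in the source may bear on it.

Working notes on the series. For the measured compounds named here, compound 2 `Cc1cnc(Nc2ccc(C(=O)Nc3c(C)cccc3C)cc2)nc1-c1cccc(OC(F)(F)F)c1` gives 1.2 nM in an assay on NIH3T3 cells for inhibition of Sonic hedgehog protein (Mus musculus), read by a luciferase reporter, with a stated time of 48 h (a higher number here means a weaker inhibitor, a lower number a stronger inhibitor), the second highest of the three numbers measured so far. Its nearest neighbour is compound 1 `Cc1cnc(Nc2ccc(C(=O)Nc3c(C)cccc3C)cc2)nc1-c1ccc(OC(F)(F)F)cc1`, which gives 1.3 nM; the step of a 1.1-fold lower number from compound 1 to compound 2 (0.03 log units; within the scatter) lies within the scatter. The furthest is compound 3 `Cc1cnc(Nc2ccc(C(=O)Nc3c(C)cccc3C)cc2)nc1-c1ccncc1`, which gives 0.54 nM; the step of a 2.2-fold lower number from compound 2 to compound 3 (0.35 log units; beyond the scatter) is modest but beyond the scatter, as is a 2.4-fold lower number from compound 1 to compound 3 (0.38 log units; beyond the scatter).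

The next compound, compound 4 `Cc1cnc(Nc2ccc(C(=O)Nc3c(C)cccc3C)cc2)nc1Cc1ccccc1`, differs from compound 2 at one place: benzyl in place of 3-(trifluoromethoxy)phenyl on an aromatic carbon. Going by the values given here, no measured step exchanges an aryl group directly on the core for one attached through a methylene, so the change is only loosely covered by what has been seen. The steps available show that exchanging the aryl group moves the number by at most a modest amount, so a step of similar or somewhat larger size in this assay is expected, more likely towards a higher number, with wide uncertainty. Compound 4 is therefore expected at 2.5 nM, within 0.8 nM to 8 nM. The expected step is a 2.1-fold higher number from compound 2 to compound 4 (0.32 log units; beyond the scatter).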

Compound 4, half-maximal inhibitory concentration: 34.3 nM
For compound 4 the middle estimate is 14-fold (1.14 log units) below the measured one; measured number above the stated range.
By their numbers in this assay, from the lowest: compound 3; then compounds 2 and 1 (each within the scatter of the next); then compound 4.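

Exchanges among directly attached rings on this aromatic carbon moved the number only slightly in this assay, so the earlier compounds gave no sign of how much this position can cost. Benzyl is the first group here to produce a large move, and it does so against all three directly attached rings (a 29-fold higher number from compound 2 to compound 4 (1.46 log units; beyond the scatter)) (a 26-fold higher number from compound 1 to compound 4 (1.42 log units; beyond the scatter)) (a 64-fold higher number from compound 3 to compound 4 (1.80 log units; beyond the scatter)). The move goes towards a higher number even though benzyl has fewer heavy atoms than 3-(trifluoromethoxy)phenyl, so heavy-atom count alone does not track the number across this pair.

Nothing on hand accounts for the size of this change. From the compounds shown here alone, it remains open whether the methylene link alone carries the loss, which a directly attached unsubstituted phenyl, an amine link or a longer chain ending in phenyl would help to separate.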